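The source may report more compounds than this note shows. Statements on the series, on what has been measured and on what is new or still open speak of the compounds shown alone.

Measured compounds:
compound 1 `O=S(=O)(/C=C/c1ccc(O)c(O)c1)CC1CCCO1` — 10500 nM in a functional assay, read by fluorescence and spectrophotometry, with a stated time of 1 h; on this read-out higher numbers stand for an effect only at larger amounts of compound and lower numbers for an effect already at smaller amounts
compound 2 `O=S(=O)(/C=C/c1ccc(O)c(O)c1)CCC1CCCC1` — 6800 nM in this assay
compound 3 `O=S(=O)(/C=C/c1ccc(O)c(O)c1)CC1CCCCO1` — 10800 nM in this assay

Compound 3 stands together with the other two in this assay: the step of a 1.0-fold higher number from compound 1 to compound 3 (0.01 log units; within the scatter) and the step of a 1.6-fold higher number from compound 2 to compound 3 (0.20 log units; within the scatter) are both within the scatter, and the step of a 1.5-fold lower number from compound 1 to compound 2 (0.19 log units; within the scatter) is as well, so the three numbers are not separated from one another. All three differ only in the group on the saturated chain carbon bound to the sulfonyl sulfur, and none of those exchanges moved the read-out beyond the scatter.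

Compound 4 `O=S(=O)(/C=C/c1ccc(O)c(O)c1)CC1CC1` is not yet measured. It differs from compound 3 by cyclopropyl in place of oxan-2-yl on a saturated chain carbon bound to a sulfonyl sulfur. Among the compounds with values here, the steps that bear on this are the two into compound 3, a 1.0-fold higher number from compound 1 to compound 3 (0.01 log units; within the scatter) and a 1.6-fold higher number from compound 2 to compound 3 (0.20 log units; within the scatter), both exchanges of a ring at the same place, and both within the scatter. On that basis no step beyond the scatter is expected in this assay, in either direction, though the cyclopropyl is smaller than any group tried so far and the three compounds are a thin basis. Compound 4 is therefore expected to give about 10000 nM in this assay, within 4000 nM to 25000 nM, which means an expected step of a 1.1-fold lower number from compound 3 to compound 4 (0.03 log units; within the scatter).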

Compound 4, half-maximal effective concentration: 10500 nM
Estimate against measurement, compound 4: 1.1-fold (0.02 log units) below, and the stated range covers the measured number.
By their numbers in this assay, from the lowest: compounds 2, 1, 4 and 3 (each within the scatter of the next).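

Cyclopropyl on a saturated chain carbon bound to a sulfonyl sulfur also stays within the scatter in this assay against each earlier group: a 1.0-fold lower number from compound 3 to compound 4 (0.01 log units; within the scatter) and no change at the digits printed from compound 1 to compound 4 (within the scatter) and a 1.5-fold higher number from compound 2 to compound 4 (0.19 log units; within the scatter) are the three steps read here. Oxan-2-yl, with 6 heavy atoms and 1 hydrogen-bond acceptor, gives way to cyclopropyl, with 3 heavy atoms and 0 hydrogen-bond acceptors, so the compounds now span these counts without any separation in the read-out. No supporting measurement is available to explain this flat result.

Since all four compounds remain within the scatter of one another, no group at this place is yet shown to move the read-out. Going by these compounds, an amine, a carboxylic acid, a phenyl ring or a longer chain at this place remains open.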